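From Dichlorophenyl Urea to a Single Trifluoromethyl

This account rests on a few compounds, and the source may have more. Where it says the series, first, only, none or still open, it means among the compounds named here.

In a functional assay on UACC-62 cells (Homo sapiens) for inhibition, read by sulforhodamine B assay, with a stated time of 48 h, tested at 1 uM (on this read-out lower numbers stand for a stronger effect and higher numbers for a weaker effect at the one concentration tested), compound 2 `COc1cc(Cl)cc(-c2nn(-c3cccc(NC(=O)Nc4ccc(Cl)c(Cl)c4)c3)cc2-c2ccncc2)c1` gives 75%, the highest of the two numbers measured, meaning the weakest effect. Compound 1 `COc1cc(Cl)cc(-c2nn(-c3cccc(NC(=O)Nc4cc(C(F)(F)F)cc(C(F)(F)F)c4)c3)cc2-c2ccncc2)c1` gives 18% in this assay, a much lower number and therefore a stronger effect, a gap beyond the scatter. Compound 3 `COc1cc(Cl)cc(-c2nn(-c3cccc(NC(=O)Nc4cccc(C(F)(F)F)c4)c3)cc2-c2ccncc2)c1` differs from compound 2 in one place: 3-(trifluoromethyl)phenyl in place of 3,4-dichlorophenyl on an amide-type nitrogen. Going by the values given here, no measured pair shows this exact change, so the size of the step can only be guessed from the two values known. The step of a number 30 percentage points lower from compound 2 to compound 3 (beyond the scatter) in this assay is expected to be downward, beyond the scatter. Compound 3 is thus estimated at 45%, within 20% to 75%.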

Compound 3, a percentage reported as activity, at one concentration (the size of the read-out at that concentration, not a potency): 70%
The estimate for compound 3 lay 25 percentage points below the measured number; low and high end bracket the measured number.
By their numbers in this assay, from the lowest: compound 1; then compounds 3 and 2 (each within the scatter of the next).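

In this assay, 3-(trifluoromethyl)phenyl in place of 3,4-dichlorophenyl gives a number 5 percentage points lower from compound 2 to compound 3 (within the scatter) and so leaves the read-out unchanged within the scatter, meaning these two groups on the amide-type nitrogen cannot be told apart here. Compound 1 carries a second trifluoromethyl where compound 3 has hydrogen, and that single change gives a number 52 percentage points higher from compound 1 to compound 3 (beyond the scatter) and shows that the second trifluoromethyl matters greatly in this series. Nothing measured here explains this gap. Still open, going by these compounds, is whether another group at that second place, such as a nitrile or a methoxy group, would match compound 1.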